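Methyl on the pendant phenyl: two cores compared

The source may report more compounds than this note shows. Statements on the series, on what has been measured and on what is new or still open speak of the compounds shown alone.

Compound 1 `COc1cc2c(Oc3ccc(NC(=O)c4cc(-c5ccccc5)ccn4)cc3F)ccnc2cc1OCCCN1CCN(C)CC1` and compound 2 `COc1cc2c(Oc3ccc(NC(=O)c4cc(-c5ccccc5C)ccn4)cc3F)ccnc2cc1OCCCN1CCN(C)CC1` share one core; compound 2 carries the change (methyl in place of hydrogen on an aromatic carbon). In a functional assay on U-87MG ATCC cells (Homo sapiens) for cytotoxicity, read by MTT assay, with a stated time of 72 h (a lower number here means a stronger inhibitor, a higher number a weaker inhibitor), compound 1 gives 1010 nM and compound 2 gives 2030 nM, a step of a 2.0-fold higher number from compound 1 to compound 2 (0.30 log units; within the scatter). Compound 3 `COc1cc2c(Oc3ccc(NC(=O)c4nccc(-c5ccccc5)n4)cc3F)ccnc2cc1OCCCN1CCCCC1` has a different core; the difference between the two cores is not broken down here. For compound 3 the entry in this assay reads "not determined" (no result reported): no number is reported. Compound 4 `COc1cc2c(Oc3ccc(NC(=O)c4nccc(-c5ccc(C)cc5)n4)cc3F)ccnc2cc1OCCCN1CCCCC1` carries the change (methyl in place of hydrogen on an aromatic carbon), the same kind of change as in compound 2 but not the same: ortho to a large group in compound 2, para to a large group in compound 4. In this assay the step of a 2.0-fold higher number from compound 1 to compound 2 (0.30 log units; within the scatter) lies within the scatter; a step of a like size, within the scatter, is expected from compound 3 to compound 4, resting on a single pair with another core. With no number for compound 3, the estimate leans on compound 1 at 1010 nM and is wide. Compound 4 is expected at about 1500 nM, between 400 nM and 6000 nM.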

Compound 4, half-maximal inhibitory concentration: 1140 nM
Compound 4: middle estimate off by 1.3-fold (0.12 log units), on the high side; measured number inside the range.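

No new step can be read between compound 3 and compound 4 in this assay, since compound 3 carries no number there. On these data alone, whether phenyl to 4-methylphenyl on this core matches the methyl step on the core of compound 1 stays open. No evidence bears on this result.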